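This account rests on a few compounds, and the source may have more. Where it says the series, first, only, none or still open, it means among the compounds named here.

Measured so far:
- compound 1, `CCC(=O)Nc1cccc(Oc2nc(Nc3ccc(N4CCN(C)CC4)cc3)ncc2Cl)c1`: 82.6%
- compound 2, `CCC(=O)Nc1cccc(Oc2nc(Nc3ccc(N4CCCC4)cc3OC)ncc2Cl)c1`: "not active" (no number reported)
- compound 3, `CCC(=O)Nc1cccc(Oc2nc(Nc3ccc(N4CCCCC4)cc3)ncc2Cl)c1`: 72.3%

All three share one core and differ only in the group attached to an aromatic carbon of a carbon-only six-membered ring. In an assay on isolated protein for inhibition of NUAK family SNF1-like kinase 2 (Homo sapiens), read by ADP-Glo, with a stated time of 60 min, tested at 10 uM, in the presence of a further agent that is not named here (on this read-out lower numbers stand for less inhibition and higher numbers for more inhibition at the one concentration tested (going by the name of the read-out)), compound 1 gives 82.6%, while compound 3 gives 72.3%, the lowest of the two numbers reported; compound 2 returned no number at all. Within the data shown here, the one measured single-point change, a number 10.3 percentage points lower from compound 1 to compound 3 (beyond the scatter), is a modest drop that lies beyond the scatter.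

Compound 4, `CCC(=O)Nc1cccc(Oc2nc(Nc3ccc(N4CCCC4)cc3)ncc2Cl)c1`, is the next step. It differs from compound 3 as follows: pyrrolidin-1-yl in place of piperidin-1-yl on an aromatic carbon. Among the measured compounds shown here, no measured pair isolates this exact change. For the measured compounds named here, compound 2 also carries pyrrolidin-1-yl but additionally a methoxy group, so its result shows only that the pair cannot be compared one-to-one. Going by the modest fall from compound 1 to compound 3 when the ring amine was altered, a further small decrease is expected for compound 4, with the step of a number 12.3 percentage points lower from compound 3 to compound 4 (beyond the scatter). Compound 4 is thus estimated at 60%, within 35% to 80%.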

Compound 4, a percentage reported as inhibition, at one concentration (the size of the read-out at that concentration, not a potency): "not active" (no number reported)
The entry for compound 4 holds no number; no gap can be computed for the estimate.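

Among these compounds, compound 4 is reported as "not active" without a number, so no step from compound 3 to compound 4 can be read. Nothing measured here accounts for this result. The compounds shown leave open how much inhibition, if any, compound 4 retains.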